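This account rests on a few compounds, and the source may have more. Where it says the series, first, only, none or still open, it means among the compounds named here.

In a functional assay on COLO 205 cells (Homo sapiens) for antiproliferative activity, read by MTT assay (on this read-out higher numbers stand for weaker inhibition and lower numbers for stronger inhibition), the measured compounds are these:
Compound 1 `COC(=O)N1CCCc2cc(S(=O)(=O)N3CC(c4ccccc4)NC3=O)ccc21` gives 4020 nM.
Compound 2 `C=CCOC(=O)N1CCCc2cc(S(=O)(=O)N3CC(c4ccccc4)NC3=O)ccc21` gives 6590 nM.
Compound 3 `NC(=O)N1CCCc2cc(S(=O)(=O)N3CC(c4ccccc4)NC3=O)ccc21` reaches only a limit of the assay, > 20000 nM.

Compound 2 stands highest of the two numbers; its nearest neighbour is compound 1, and the step of a 1.6-fold higher number from compound 1 to compound 2 (0.21 log units; within the scatter). Compound 4 `O=C(CCl)NC(=O)N1CCCc2cc(S(=O)(=O)N3CC(c4ccccc4)NC3=O)ccc21` differs from compound 2 by ((chloromethyl)carbonyl)amino in place of allyloxy on a carbonyl carbon. Among the compounds with values here, no measured step matches this change exactly. The closest are an at least 3.0-fold higher number from compound 2 to compound 3 (0.48 log units; beyond the scatter) and an at least 4.9-fold higher number from compound 1 to compound 3 (0.69 log units; beyond the scatter), where amino replaces an alkoxy group on the same carbonyl carbon; compound 3 sits at the limit of > 20000 nM in this assay, at which 1 of the 3 values shown sits. Since compound 4 likewise bears a nitrogen on that carbonyl carbon, a weakening step is expected, a 2.3-fold higher number from compound 2 to compound 4 (0.36 log units; beyond the scatter). Compound 4 is therefore estimated at 15000 nM, in a range from 5000 nM to 40000 nM.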

Compound 4, half-maximal inhibitory concentration: 9910 nM
The estimate for compound 4 lay 1.5-fold (0.18 log units) above the measured number, and the stated range covers the measured number.
By their numbers in this assay, from the lowest: compounds 1, 2 and 4 (each within the scatter of the next, the first and the last beyond it). At a limit, above all of these: compound 3.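

Compound 4 shows that a nitrogen on this carbonyl carbon can still give a number inside the range of the assay, with a 1.5-fold higher number from compound 2 to compound 4 (0.18 log units; within the scatter) and a 2.5-fold higher number from compound 1 to compound 4 (0.39 log units; beyond the scatter). Compound 3 stands at a limit of the assay: the limit of > 20000 nM in this assay, at which 1 of the 4 values shown sits. Placing (chloromethyl)carbonyl on its amide-type nitrogen gives an at least 2.0-fold lower number from compound 3 to compound 4 (0.30 log units; that floor lies within the scatter), so the true size of this step stays unfixed.

Going by these compounds, what the chlorine itself contributes remains open. An acetyl group on that nitrogen would separate its part from that of the added carbonyl.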